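Fluoro removal from the fused ring of compound 1

A few compounds are considered here, and "the series" means these few. Any claim that something is new, unique, unknown or untested is made for them only; others in the source may bear on it.

For the measured compounds named here, compound 1 `N#Cc1ccc2c(Oc3ccccc3OCCn3ccc(=O)[nH]c3=O)cc(F)cc2c1` stands at the lower of the two numbers so far in a physicochemical assay for solubility, using the shake flask method, at pH 6.5 (on this read-out lower numbers stand for lower solubility and higher numbers for higher solubility), where compound 1 gives 9.1 ug/mL. Going by the values given here, its nearest neighbour is compound 2 `N#Cc1ccc2c(Oc3ccc(F)cc3OCCn3ccc(=O)[nH]c3=O)cc(F)cc2c1`, which in this assay gives 82.9 ug/mL; the only measured step, fluoro in place of hydrogen on an aromatic carbon, is a 9.1-fold higher number from compound 1 to compound 2 (0.96 log units; beyond the scatter).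

Compound 3 `N#Cc1ccc2c(Oc3ccccc3OCCn3ccc(=O)[nH]c3=O)cccc2c1` differs from compound 1 by hydrogen in place of fluoro on an aromatic carbon. Among the compounds with values here, no measured step touches this place: the step from compound 1 to compound 2 concerns a fluoro entering on the other ring, not one leaving the fused system, so it bears on the present change only as a sign that a single fluoro can move this read-out beyond the scatter. Within the data shown here, with no step in the matching direction or place, the change from compound 1 to compound 3 in this assay is expected to be small, likely within or just beyond the scatter, with no firm direction, and the estimate is set slightly above compound 1 as a 1.5-fold higher number from compound 1 to compound 3 (0.19 log units; within the scatter). Compound 3 is therefore expected to give about 14 ug/mL in this assay, within a range of 5 ug/mL to 45 ug/mL.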

Compound 3, solubility: 4.3 ug/mL
The estimate for compound 3 lay 3.3-fold (0.51 log units) above the measured number; the measured number lies below the stated range.
By their numbers in this assay, from the lowest: compound 3; then compound 1; then compound 2.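

In this assay, hydrogen in place of fluoro on the fused system gives a 2.1-fold lower number from compound 1 to compound 3 (0.33 log units; beyond the scatter), so this place is not silent on the read-out. The fluoro here, on an aromatic carbon meta to a large group and para to a fused ring, now has a measured step of its own, modest in size. Alongside a 9.1-fold higher number from compound 1 to compound 2 (0.96 log units; beyond the scatter), where fluoro enters on the other ring, both steps from compound 1 run the same way, with fluoro going with the higher number at each of the two places; neither listed step goes against this, but the pattern rests on these three compounds alone.

No supporting measurement is available to explain either step.

Still open, from the compounds shown here alone, is whether this place tolerates anything beyond fluoro and hydrogen, for example a chloro, a methoxy or an amine on the same aromatic carbon. Also open, going by these compounds, is whether the two fluoro steps keep their direction when the nitrile gives way to a carboxylic acid.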